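From 4-fluorophenyl to cyclopropyl on a carbonyl

The compounds below may be only part of what the source reports. "The series", "measured", "known", "first", "only" and "open" are said of these compounds alone.

In a functional assay on HCT-116 cells (Homo sapiens) for inhibition, read by MTT assay, with a stated time of 48 h (on this read-out higher numbers stand for weaker inhibition and lower numbers for stronger inhibition), compound 1 `COc1ccc(CSc2nnc(-c3cc(OC)c(OC)c(OC)c3)n2-c2ccc(N(C)C)cc2)cc1` gives 1150 nM and compound 2 `COc1cc(-c2nnc(SCC(=O)c3ccc(F)cc3)n2-c2ccc(N(C)C)cc2)cc(OC)c1OC` gives 31100 nM, the higher of the two numbers and so the weaker inhibition. Compound 3 `COc1cc(-c2nnc(SCC(=O)C3CC3)n2-c2ccc(N(C)C)cc2)cc(OC)c1OC` carries cyclopropyl in place of 4-fluorophenyl on a carbonyl carbon. Among the compounds with values here, the only measured step is large (a 27-fold higher number from compound 1 to compound 2 (1.43 log units; beyond the scatter)), but it swapped 4-methoxyphenyl for (4-fluorophenyl)carbonyl, and compound 3 keeps the carbonyl. No measurement tests this swap directly, so the expected result (a 1.2-fold lower number from compound 2 to compound 3 (0.09 log units; within the scatter)) is no step beyond the scatter. Compound 3 is estimated at 25000 nM (expected range 8000 nM to 70000 nM).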

Compound 3, half-maximal inhibitory concentration: > 60000 nM
Compound 3: a limit, no number (the forecaster's own chance of this, stated with the estimate: 15%); middle value at least 2.4-fold (0.38 log units) from the limit.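

In this assay compound 3 reaches a limit of the assay, not a number: the limit of > 60000 nM in this assay, at which 1 of the 3 values shown sits.

Replacing 4-fluorophenyl with cyclopropyl on the carbonyl carbon brings no recovery of inhibition, giving an at least 1.9-fold higher number from compound 2 to compound 3 (0.28 log units; that floor lies within the scatter), though that floor alone does not establish a real loss. The chain with the smaller ring on its carbonyl also stays far weaker than the one ending in 4-methoxyphenyl, with an at least 52-fold higher number from compound 1 to compound 3 (1.71 log units; beyond the scatter).

As far as these compounds go, how far the true value of compound 3 lies past its limit remains open. So does whether an amine on the carbonyl carbon would restore inhibition.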